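A few compounds are considered here, and "the series" means these few. Any claim that something is new, unique, unknown or untested is made for them only; others in the source may bear on it.

Three compounds share one core and differ only in the chain on the ring nitrogen and in the halogen on the benzene ring. Compound 1 `CCCCn1c(/N=C/c2ccc(Cl)cc2)c(C#N)sc1=S` carries a butyl chain and a chlorine; in an assay on HEK293 cells for displacement of a labelled ligand from adenosine receptor A1 (Homo sapiens), read by scintillation counting, with a stated time of 60 min (on this read-out higher numbers stand for weaker inhibition and lower numbers for stronger inhibition), compound 1 gives 24600 nM. Compound 2 `CCn1c(/N=C/c2ccc(Br)cc2)c(C#N)sc1=S` carries an ethyl chain and a bromine, and in this assay compound 2 gives 0.00074 nM. Compound 3 `CCCn1c(/N=C/c2ccc(Br)cc2)c(C#N)sc1=S` carries a propyl chain and a bromine, and in this assay compound 3 gives 607 nM, the second highest of the three numbers, closer to compound 1 than to compound 2.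

Going by the values given here, the one measured step that changes only the chain is an 820000-fold higher number from compound 2 to compound 3 (5.91 log units; beyond the scatter), an ethyl lengthened to a propyl. The unmeasured compound 4 `CCCCn1c(/N=C/c2ccc(Br)cc2)c(C#N)sc1=S` takes that idea one bond further: methyl in place of hydrogen on a saturated chain carbon, three bonds along the chain from an aromatic nitrogen, which turns the propyl into a butyl. Compound 1 is the butyl analogue with chlorine in place of bromine, and its number sits well above that of compound 3. On that basis compound 4 is expected to show a further rise in this assay, estimated at a 25-fold higher number from compound 3 to compound 4 (1.39 log units; beyond the scatter), giving an expected value of 15000 nM within a range from 3000 nM to 80000 nM.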

Compound 4, inhibition constant: 0.1 nM
For compound 4 the middle estimate is 150000-fold (5.18 log units) above the measured one; measured number below the stated range.
By their numbers in this assay, from the lowest: compound 2; then compound 4; then compound 3; then compound 1.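

In this assay the chain on the ring nitrogen does not push the number one way: after the rise on going from ethyl to propyl, adding a methyl to make butyl gives a 6100-fold lower number from compound 3 to compound 4 (3.78 log units; beyond the scatter) and so reverses much of that rise, although ethyl to butyl overall still leaves a 140-fold higher number from compound 2 to compound 4 (2.13 log units; beyond the scatter) on this read-out. With the butyl chain held constant, bromo in place of chloro on the benzene ring gives a 250000-fold lower number from compound 1 to compound 4 (5.39 log units; beyond the scatter). Nothing available explains either swing.

A pentyl chain would show whether the up-and-down pattern continues beyond butyl. A fluoro group on the benzene ring, or chloro paired with the ethyl chain, would show whether the halogen matters as much with other chains.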